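This account rests on a few compounds, and the source may have more. Where it says the series, first, only, none or still open, it means among the compounds named here.

Compound 2 `CC1=CC[C@@H]([C@@](C)(O)CCCC(C)(C)NC(=S)N/N=C\c2ccc(N(C)C)cc2)CC1` and compound 1 `CC1=CC[C@@H]([C@@](C)(O)CCCC(C)(C)NC=S)CC1` share the same core, and both have been tested in a functional assay on HT-29 cells (Homo sapiens) for cytotoxicity, read by sulforhodamine B assay; a higher number here means a weaker inhibitor of growth, a lower number a stronger inhibitor of growth. Compound 1 gives 11400 nM, and compound 2 gives 27700 nM; of these two numbers compound 2 stands highest, so it is the weaker inhibitor of growth of the pair, and the gap to compound 1 lies beyond the usual scatter. Among the compounds with values here, no step between measured compounds that differ in a single place is known here, so nothing yet shows how a change on the outer aromatic ring moves the result. Compound 3 `CC1=CC[C@@H]([C@@](C)(O)CCCC(C)(C)NC(=S)N/N=C\c2cccc(Cl)c2)CC1` has not been measured. It differs from compound 2 in one place: 3-chlorophenyl in place of 4-(dimethylamino)phenyl on a carbon with a double bond to nitrogen. Lacking a measured step of this kind, the expected change is a 1.3-fold lower number from compound 2 to compound 3 (0.10 log units; within the scatter), nothing that should reach beyond the scatter in either direction. In this assay compound 3 is therefore estimated at 22000 nM, with a range from 8000 nM to 60000 nM.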

Compound 3, concentration for 50% growth inhibition: 6890 nM
Estimate against measurement, compound 3: 3.2-fold (0.50 log units) above, and the stated range ends above it.
By their numbers in this assay, from the lowest: compounds 3 and 1 (each within the scatter of the next); then compound 2.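

In this assay, 3-chlorophenyl in place of 4-(dimethylamino)phenyl on a carbon with a double bond to nitrogen gives a 4.0-fold lower number from compound 2 to compound 3 (0.60 log units; beyond the scatter). Within the data shown here, this is the first measured step at this position, and it shows that the aromatic group here can shift growth inhibition beyond the scatter, with compound 3 the stronger inhibitor of the pair. Nothing available explains this shift.

The step alters both the group on the ring and its place on that ring, so it cannot say which of the two matters. Going by these compounds, a plain phenyl, a 4-chlorophenyl or a 3-(dimethylamino)phenyl would separate those two changes, and whether a group such as a methoxy or a nitrile at this position would move the number further remains open.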